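Moving the Bromine Around the Sulfone Aryl Ring

A few compounds are considered here, and "the series" means these few. Any claim that something is new, unique, unknown or untested is made for them only; others in the source may bear on it.

Compound 3, `CCCCN(O)C(=O)Nc1cc([C@@H]2CC[C@@H](c3cc(OC)c(OC)c(OC)c3)O2)cc(OC)c1OCCS(=O)(=O)c1ccc(Br)cc1`, was tested in a functional assay on the whole organism for inhibition, with Mus musculus as the target, at a dose of 3 mg/kg (a higher number here means more inhibition at the dose given (going by the name of the read-out), a lower number less inhibition), where compound 3 gives 29%. Among the three compounds measured so far it stands second highest. Compound 1, `CCCCN(O)C(=O)Nc1cc([C@@H]2CC[C@@H](c3cc(OC)c(OC)c(OC)c3)O2)cc(OC)c1OCCSc1ccc(Br)cc1`, gives 11% in this assay, and compound 2, `CCCCN(O)C(=O)Nc1cc([C@@H]2CC[C@@H](c3cc(OC)c(OC)c(OC)c3)O2)cc(OC)c1OCCS(=O)(=O)c1c(F)c(F)cc(F)c1F`, gives 50%. Two measured steps lead to compound 3: a number 18 percentage points higher from compound 1 to compound 3 (beyond the scatter), and a number 21 percentage points lower from compound 2 to compound 3 (beyond the scatter). Both show that what sits at the sulfur end of the chain shifts the read-out by a modest amount, and that the shift can go either way.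

Compound 4, `CCCCN(O)C(=O)Nc1cc([C@@H]2CC[C@@H](c3cc(OC)c(OC)c(OC)c3)O2)cc(OC)c1OCCS(=O)(=O)c1ccccc1Br`, differs from compound 3 in one place: 2-bromophenyl in place of 4-bromophenyl on a sulfonyl sulfur. Going by the values given here, neither measured step moves the bromine around the ring, so this change has no direct precedent among the compounds here. The two steps only suggest that alterations in this part of the molecule move the number modestly. The expected step is therefore small and of uncertain direction, a number 1 percentage points lower from compound 3 to compound 4 (within the scatter). The estimate for compound 4 in this assay is 28%, within a range from 10% to 50%.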

Compound 4, a percentage reported as inhibition, in the whole organism at one dose (the size of the read-out at that dose, not a potency): 60%
Compound 4: middle estimate off by 32 percentage points, on the low side; the measured number lies above the stated range.
By their numbers in this assay, from the lowest: compound 1; then compound 3; then compounds 2 and 4 (each within the scatter of the next).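

Where the bromine sits on the ring matters in this assay: 2-bromophenyl in place of 4-bromophenyl on a sulfonyl sulfur, with no atom gained or lost, is a large step (a number 31 percentage points higher from compound 3 to compound 4 (beyond the scatter)). Going by these compounds alone, two quite different rings on the sulfonyl sulfur now read alike (a number 10 percentage points higher from compound 2 to compound 4 (within the scatter)), and the whole change from (4-bromophenyl)sulfanyl to (2-bromophenyl)sulfonyl spans the widest step so far (a number 49 percentage points higher from compound 1 to compound 4 (beyond the scatter)). Nothing available explains how moving one bromine produces a step of this size.

As far as these compounds go, it remains open whether 3-bromophenyl, 2-chlorophenyl or 2-methylphenyl on the sulfonyl sulfur would read like 2-bromophenyl or like 4-bromophenyl. Also open, from the compounds shown here alone, is whether (2-bromophenyl)sulfanyl would stay as low as (4-bromophenyl)sulfanyl, which would show how much the sulfonyl group contributes with the bromine in this new place.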